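This account rests on a few compounds, and the source may have more. Where it says the series, first, only, none or still open, it means among the compounds named here.

Measured in a physicochemical assay for solubility, at pH 6.8; on this read-out higher numbers stand for higher solubility and lower numbers for lower solubility:

- Compound 1 `CN(C)Cc1ccc(-c2cnc(N)c(C(=O)NC3CCCCC3)n2)cc1`: 190000 nM
- Compound 2 `CC(C)N1CCN(Cc2ccc(-c3cnc(N)c(C(=O)N[C@H]4CC[C@H](O)CC4)n3)cc2)CC1`: 830000 nM
- Compound 3 `CC(C)N1CCN(Cc2ccc(-c3cnc(N)c(C(=O)NC[C@@](C)(O)C(F)(F)F)n3)cc2)CC1`: > 1000000 nM, a limit of the assay

Compound 1 has the lower of the two actual numbers, and its gap to compound 2 lies beyond the scatter. Compound 4 `CC(O)CNC(=O)c1nc(-c2ccc(CN(C)C)cc2)cnc1N` has not yet been measured. It differs from compound 1 by one change, 2-hydroxypropyl in place of cyclohexyl on an amide-type nitrogen.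

For the measured compounds named here, no measured step makes this exact change. The closest is an at least 1.2-fold higher number from compound 2 to compound 3 (0.08 log units; that floor lies within the scatter), which replaces 4-hydroxycyclohexyl with 2-hydroxy-2-(trifluoromethyl)propyl, and it offers only weak guidance. Compound 2, which carries a hydroxylated group on the amide-type nitrogen, gives 830000 nM, but it also differs from compound 1 elsewhere. A moderate rise in this assay is therefore expected, with the expected step being a 3.2-fold higher number from compound 1 to compound 4 (0.50 log units; beyond the scatter). For compound 4 the estimated value is 600000 nM, with an expected range of 250000 nM to 1000000 nM.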

Compound 4, solubility: > 1000000 nM
Compound 4: a limit, no number; the forecaster's own chance of this, stated with the estimate: 30%; middle value at least 1.6-fold (0.22 log units) away from the limit.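

In this assay, changing cyclohexyl to 2-hydroxypropyl on the amide-type nitrogen, with the rest of compound 1 left as it is, gives an at least 5.2-fold higher number from compound 1 to compound 4 (0.72 log units; beyond the scatter). For the compounds shown here, this is the first reading of a change at this position that clears the scatter: the earlier step there, an at least 1.2-fold higher number from compound 2 to compound 3 (0.08 log units; that floor lies within the scatter), started from 4-hydroxycyclohexyl, and compound 2 differs from compound 1 in more than one place. Compound 4 sits at a limit of the assay and not at a number, so the new step is only a floor: the limit of > 1000000 nM in this assay, at which 2 of the 4 values shown sit.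

The compounds shown leave open how much of the step goes with the hydroxyl of 2-hydroxypropyl and how much with the loss of cyclohexyl. A plain propyl chain at the same nitrogen, or an amine or a carboxylic acid in place of that hydroxyl, would begin to separate the two.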